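This account rests on a few compounds, and the source may have more. Where it says the series, first, only, none or still open, it means among the compounds named here.

Measured so far:
Compound 1 `CCOc1ccc(/C=C(\C(=O)c2ccc(Cl)cc2)S(=O)(=O)Cc2ccc(C)cc2)cc1OC`: 10000 nM
Compound 2 `CCOc1ccc(/C=C(\C(=O)c2ccc(Cl)cc2)S(=O)(=O)c2ccc(C)cc2)cc1OC`: 1000 nM
Compound 3 `CCOc1ccc(/C=C(/SCc2ccc(C)cc2)C(=O)c2ccc(Cl)cc2)cc1OC`: 25000 nM

These numbers come from a functional assay on DU-145 cells (Homo sapiens) for inhibition, read by trypan blue exclusion, with a stated time of 96 h; on this read-out higher numbers stand for weaker inhibition of growth and lower numbers for stronger inhibition of growth. Compound 1 stands second highest of the three: compound 3 lies above it by a 2.5-fold higher number from compound 1 to compound 3 (0.40 log units; beyond the scatter), while compound 2 lies below it by a 10-fold lower number from compound 1 to compound 2 (1.00 log units; beyond the scatter). Both measured steps alter the sulfur-bearing group, leaving the 4-ethoxy-3-methoxyphenyl untouched. Compound 4 `Cc1ccc(CS(=O)(=O)/C(=C/c2ccc(C)s2)C(=O)c2ccc(Cl)cc2)cc1` differs from compound 1 at that very group: 5-methylthiophen-2-yl in place of 4-ethoxy-3-methoxyphenyl on a double-bonded chain carbon bound to a double-bonded chain carbon. For the measured compounds named here, no measured step touches this position, so the data give no direct guide, and a step of either direction in this assay cannot be excluded. With nothing to anchor a direction, compound 4 is expected to stay near compound 1, a step of about a 1.2-fold higher number from compound 1 to compound 4 (0.08 log units; within the scatter). The estimate for compound 4 is 12000 nM, ranging from 3000 nM to 50000 nM.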

Compound 4, concentration for 50% growth inhibition: 25000 nM
Compound 4: the middle estimate sits 2.1-fold (0.32 log units) below what was measured; measured number inside the range.
By their numbers in this assay, from the lowest: compound 2; then compound 1; then compounds 3 and 4 (each within the scatter of the next).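

For the compounds shown here, putting 5-methylthiophen-2-yl in place of 4-ethoxy-3-methoxyphenyl gives the first reading at this position, and in this assay it weakens growth inhibition, with a 2.5-fold higher number from compound 1 to compound 4 (0.40 log units; beyond the scatter) as the step. This position therefore responds to change, though only modestly in this one example. Nothing measured here offers a reason for the shift.

As far as these compounds go, whether the loss comes from the change of ring or from losing the ethoxy and methoxy groups stays open, and a plain phenyl or a 4-aminophenyl could help separate the two. Also open, from the compounds shown here alone, is whether the same swap would act alike on the (4-methylphenyl)sulfonyl series of compound 2.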